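Compound 3 to compound 4: bromo on the phenyl

The source may hold more compounds than are shown below. What is called first, only, known or untested is meant among the compounds shown, and "the series" means these compounds.

Of the compounds shown here, three have been read so far in a functional assay on ECa-109 cells (Homo sapiens) for cytotoxicity, read by MTT assay, with a stated time of 48 h (on this read-out higher numbers stand for weaker inhibition and lower numbers for stronger inhibition), and none of them gives a number. Compound 1 (`COc1ccc(-c2c[nH]c(=O)n2-c2cc(OC)c(OC)c(OC)c2)cc1N`) gives > 50000 nM, which is a limit of the assay. Compound 2 (`COc1ccc(-c2cn(C(=O)Nc3cc(OC)c(OC)c(OC)c3)c(=O)n2-c2cc(OC)c(OC)c(OC)c2)cc1N`) gives > 50000 nM, which is also a limit. Compound 3 (`COc1cc(-n2c(-c3ccccc3)cn(C(C)=O)c2=O)cc(OC)c1OC`) gives > 50000 nM, again a limit. Its place is the limit of > 50000 nM in this assay, at which 3 of the 3 values shown sit.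

Compound 4 (`COc1cc(-n2c(-c3ccc(Br)cc3)cn(C(C)=O)c2=O)cc(OC)c1OC`) follows from compound 3 by the change of phenyl to 4-bromophenyl, with bromo in place of hydrogen on an aromatic carbon, para to a large group: bromo in place of hydrogen on an aromatic carbon. Within the data shown here, no measured pair shows the size of such a change. With only limits to go on, the expected step of a number no higher from compound 3 to compound 4 (the limit leaves the size open) in this assay is none beyond the scatter, so no clear shift in either direction is expected. For compound 4 the estimated value is 50000 nM, with an expected range from 20000 nM to 100000 nM.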

Compound 4, half-maximal inhibitory concentration: 3800 nM
Beside the measured number, compound 4's estimate is 13-fold (1.12 log units) above it, and the stated range ends above it.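

Bromo in place of hydrogen on an aromatic carbon, para to a large group, is the first change shown to bring a compound off the limit in this assay, with an at least 13-fold lower number from compound 3 to compound 4 (1.11 log units; beyond the scatter). The earlier compounds shown here gave no sign that this place on the phenyl ring could shift the read-out at all. The step is only a lower bound on the true size, and compound 4 is the one compound shown with a number rather than a limit: the limit of > 50000 nM in this assay, at which 3 of the 4 values shown sit.

Open, going by these compounds, is whether chloro, methyl or an amine at the same place would give a similar number, or whether the shift is particular to bromo. Also open, on these data alone, is whether the bromo step would hold if the acetyl group of compound 4 gave way to a longer acyl chain.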